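Chloro Replaces Fluoro on a Shared Core

This account rests on a few compounds, and the source may have more. Where it says the series, first, only, none or still open, it means among the compounds named here.

Measured so far in a functional assay on PC-3 cells (Homo sapiens) for antiproliferative activity, read by MTT assay, with a stated time of 48 h; on this read-out higher numbers stand for weaker inhibition and lower numbers for stronger inhibition: compound 1 `CN1C(=O)C2(C(C#N)=C(N)Oc3cc4oc(-c5ccccc5)cc(=O)c4c(O)c32)c2cc(Cl)ccc21` gives 21400 nM. Compound 2 `COc1ccc2c(c1)C1(C(=O)N2Cc2ccccc2)C(C#N)=C(N)Oc2cc3oc(-c4ccccc4)cc(=O)c3c(O)c21` gives > 50000 nM, which is a limit of the assay and not a number. Compound 3 `N#CC1=C(N)Oc2cc3oc(-c4ccccc4)cc(=O)c3c(O)c2C12C(=O)N(Cc1ccccc1)c1ccc(F)cc12` gives > 50000 nM, again a limit and not a number.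

Compound 3 therefore sits at the limit of > 50000 nM in this assay, at which 2 of the 3 values shown sit. Within the data shown here, the only single-place step, from compound 2 to compound 3, is a step that the two limits leave unreadable from compound 2 to compound 3. Compound 4 `N#CC1=C(N)Oc2cc3oc(-c4ccccc4)cc(=O)c3c(O)c2C12C(=O)N(Cc1ccccc1)c1ccc(Cl)cc12` differs from compound 3 by chloro in place of fluoro on an aromatic carbon. No readable step bears on this change, and compound 1 shares the chloro but differs elsewhere. The step from compound 3 to compound 4 is expected to be a step that the limit leaves unreadable from compound 3 to compound 4. Compound 4 is estimated at 60000 nM, within 20000 nM to 180000 nM, most likely again reported only as a limit.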

Compound 4, half-maximal inhibitory concentration: > 50000 nM
Compound 4: no number, only a limit (the forecaster's own chance of this, stated with the estimate: 70%); the middle value lies beyond the limit too.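

In this assay, compound 4 gives only a limit and not a number: the limit of > 50000 nM in this assay, at which 3 of the 4 values shown sit. The steps among compound 2, compound 3 and compound 4 therefore cannot be read, so this aromatic carbon shows no order among fluoro, chloro and methoxy. The shared chloro does give one readable comparison, with phenyl in place of hydrogen on the saturated chain carbon bound to the amide-type nitrogen: an at least 2.3-fold higher number from compound 1 to compound 4 (0.36 log units; beyond the scatter).

As far as these compounds go, whether these three groups differ at all on this carbon stays open. So does how an amine or a carboxylic acid there would read.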